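The source may hold more compounds than are shown below. What is called first, only, known or untested is meant among the compounds shown, and "the series" means these compounds.

Of the compounds shown here, two have been measured in an assay for binding affinity to Adrenergic receptor alpha-1 (Rattus norvegicus); on this read-out lower numbers stand for stronger inhibition and higher numbers for weaker inhibition. Compound 1 `O=c1[nH]c2cc[nH]c2c(=O)n1CCCN1CCN(c2ccccc2Cl)CC1` gives 59.8 nM, and compound 2 `COc1ccccc1N1CCN(CCCn2c(=O)[nH]c3cc(-c4ccccc4)[nH]c3c2=O)CC1` gives 1.23 nM, the lowest of the two numbers and clearly apart from compound 1, beyond the scatter. Compound 3 `O=c1[nH]c2cc(-c3ccccc3)[nH]c2c(=O)n1CCCN1CCN(c2ccccc2Cl)CC1` shares the core of compound 2 and differs from it in one place: chloro in place of methoxy on an aromatic carbon. Among the measured compounds shown here, compound 1 also carries the chloro group, but it lacks the phenyl on the core, so no single step joins it to compound 3. A modest weakening is expected in this assay, a 2.4-fold higher number from compound 2 to compound 3 (0.39 log units; beyond the scatter). Compound 3 is therefore estimated at 3 nM, with a range from 1 nM to 10 nM.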

Compound 3, inhibition constant: 62.4 nM
Compound 3: middle estimate off by 21-fold (1.32 log units), on the low side; measured number above the stated range.
By their numbers in this assay, from the lowest: compound 2; then compounds 1 and 3 (each within the scatter of the next).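

In this assay, chloro in place of methoxy on an aromatic carbon, ortho to a large group, gives a 51-fold higher number from compound 2 to compound 3 (1.71 log units; beyond the scatter) with the phenyl on the shared core, so this one change weighs heavily here. With the chloro group in both compounds, phenyl in place of hydrogen gives a 1.0-fold higher number from compound 1 to compound 3 (0.02 log units; within the scatter) and so leaves the number unmoved. No measurement in hand explains the large step.

As far as these compounds go, whether the phenyl matters alongside the 2-methoxyphenyl group stays open. So does how a fluoro, methyl or ethoxy group would read at this place.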